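The source may report more compounds than this note shows. Statements on the series, on what has been measured and on what is new or still open speak of the compounds shown alone.

Measured compounds:
- compound 1, `CC(C)[C@H](NC(=O)CCN(C)C)c1cccc(F)c1N1CCN(C(=O)[C@@H]2CN(C(C)C)C[C@H]2c2cc(F)c(F)c(F)c2)CC1`, 250 nM
- compound 2, `Cc1ccc(N2CCN(C(=O)[C@@H]3CN(C4CCOCC4)C[C@H]3c3ccc(Cl)cc3)CC2)c([C@@H](NC(=O)[C@H](C)N)C(C)C)c1`, 1 nM

Both were tested in an assay on HEK293 cells for displacement of a labelled ligand from Melanocortin receptor 4 (Homo sapiens); a higher number here means a weaker inhibitor, a lower number a stronger inhibitor. Compound 1 gives 250 nM, the higher of the two numbers, so it is the weaker of the pair. Compound 2 gives 1 nM, a far lower number, and the gap between them lies well beyond the usual scatter. For the measured compounds named here, the two compounds differ in many places at once, so what the gap shows is only that the two values stand far apart, not which part of the structure accounts for it.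

Compound 3, `CC(C)[C@H](NC(=O)CCN(C)C)c1cccc(F)c1N1CCN(C(=O)[C@@H]2CN(C(C)C)C[C@H]2c2ccc(C(F)(F)F)cc2F)CC1`, has not yet been measured. It differs from compound 1 in one place: 2-fluoro-4-(trifluoromethyl)phenyl in place of 3,4,5-trifluorophenyl on a saturated ring carbon. Going by the values given here, no measured pair shows a change of this kind on its own, so the size of the step from compound 1 to compound 3 has to be judged from the structural change alone. The aromatic ring keeps fluorine and gains a trifluoromethyl group. The expectation is a modest step, if any, and the step from compound 1 to compound 3 is estimated as a 1.7-fold lower number from compound 1 to compound 3 (0.22 log units; within the scatter). For compound 3 the estimate is 150 nM, with a range from 40 nM to 600 nM.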

Compound 3, inhibition constant: 61 nM
Estimate against measurement, compound 3: 2.5-fold (0.39 log units) above; the measured number falls inside the stated range.
By their numbers in this assay, from the lowest: compound 2; then compound 3; then compound 1.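

In this assay this saturated ring carbon turns out to be sensitive to what the aromatic ring carries: with everything else in the molecule held fixed, 2-fluoro-4-(trifluoromethyl)phenyl in place of 3,4,5-trifluorophenyl gives a 4.1-fold lower number from compound 1 to compound 3 (0.61 log units; beyond the scatter) and so a stronger inhibitor. For the compounds shown here, this is the first step here that can be read as a single change, which the wide gap between the two earlier compounds could not offer, as they differ in many places at once. No measurement shown here accounts for the step, so its cause remains unknown.

The swap alters the placement of the fluorines and brings in a trifluoromethyl group at the same time, so the compounds shown cannot say which of these carries the step. They also leave open how the same position would respond to an aromatic ring bearing a nitrile or a methoxy group in place of these fluorinated substituents.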